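Taking the hydroxy group off compound 3

This account rests on a few compounds, and the source may have more. Where it says the series, first, only, none or still open, it means among the compounds named here.

In a functional assay on PC-6 cells (Homo sapiens) for cytotoxicity, read by MTT assay, with a stated time of 3 days (on this read-out higher numbers stand for weaker inhibition and lower numbers for stronger inhibition), compound 3 `CC(C)(C)c1cc2c(N/N=C/c3ccc(O)cc3)ncnc2s1` gives > 10 ug/mL, which is a limit and not a number. Compound 3 thus stands at the limit of > 10 ug/mL in this assay, at which 1 of the 3 values shown sits.

The next structure, compound 4 `CC(C)(C)c1cc2c(N/N=C/c3ccccc3)ncnc2s1`, differs from it in one place: hydrogen in place of hydroxy on an aromatic carbon. This puts hydrogen in place of hydroxy on an aromatic carbon, turning 4-hydroxyphenyl into phenyl.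

Two measured relatives help. Compound 1 `CC(C)(C)c1cc2c(N/N=C/c3ccc(CO)cc3)ncnc2s1`, with hydroxymethyl on that carbon, reads 0.556 ug/mL. Compound 2 `CNCc1ccc(/C=N/Nc2ncnc3sc(C(C)(C)C)cc23)cc1`, with (methylamino)methyl there, reads 0.044 ug/mL. For the measured compounds named here, the steps that bear on the change are large: an at least 17-fold higher number from compound 1 to compound 3 (1.25 log units; beyond the scatter), and an at least 220-fold higher number from compound 2 to compound 3 (2.35 log units; beyond the scatter). The remaining step, a 13-fold lower number from compound 1 to compound 2 (1.10 log units; beyond the scatter), shows that even these two groups are far apart.

So the group on this carbon clearly matters, but no measured step places hydrogen there, and the starting point is only a limit. Going by an at least 17-fold higher number from compound 1 to compound 3 (1.25 log units; beyond the scatter) and an at least 220-fold higher number from compound 2 to compound 3 (2.35 log units; beyond the scatter) both compounds without the hydroxy group read far lower than compound 3, so a lower number is expected once hydroxy leaves, though probably not as low as either relative. The expected change in this assay is an at least 5.0-fold lower number from compound 3 to compound 4 (0.69 log units; beyond the scatter), toward stronger inhibition. For compound 4 the estimated value is 2 ug/mL, with an expected range from 0.3 ug/mL to 12 ug/mL.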

Compound 4, half-maximal inhibitory concentration: 6.54 ug/mL
Estimate against measurement, compound 4: 3.3-fold (0.51 log units) below; low and high end bracket the measured number.
By their numbers in this assay, from the lowest: compound 2; then compound 1; then compound 4. At a limit, above all of these: compound 3.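

Hydrogen on this carbon gives a far weaker compound in this assay than either of the two groups with a chain carbon, with a 12-fold higher number from compound 1 to compound 4 (1.07 log units; beyond the scatter) and a 150-fold higher number from compound 2 to compound 4 (2.17 log units; beyond the scatter). This gives the position a measured baseline and shows that the strength of those two relatives comes from what their groups add, not from the shared core alone. Taking the hydroxy group away, by contrast, gives no gain that can be firmly stated, with an at least 1.5-fold lower number from compound 3 to compound 4 (0.18 log units; that floor lies within the scatter). The reading of compound 3 is a limit and not a number, and the true size of this step stays unknown: the limit of > 10 ug/mL in this assay, at which 1 of the 4 values shown sits.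

Only a few groups on this carbon are shown, so it remains open whether a plain aminomethyl group or a longer chain ending in an amine would match the (methylamino)methyl group of the strongest relative. On these data alone, it is also open whether a methoxy group or a carboxylic acid on this carbon would read closer to hydroxy or to hydrogen.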